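The source may hold more compounds than are shown below. What is called first, only, known or untested is meant among the compounds shown, and "the series" means these compounds.

Among the compounds with values here, in a functional assay on P388 cells (Mus musculus) for cytotoxicity (a lower number here means a stronger inhibitor, a higher number a weaker inhibitor), compound 1 `Cc1cc(-c2c(F)cc3c(=O)ccn(C4CC4)c3c2F)cc(C)n1` gives 15000 nM for the shared core, and compound 2 `Cc1cc(-c2c(F)cc3c(=O)c(Cc4ncc[nH]4)cn(C4CC4)c3c2F)cc(C)n1` gives 1100 nM as the lower of the two numbers so far. Within the data shown here, the only measured step is a 14-fold lower number from compound 1 to compound 2 (1.13 log units; beyond the scatter) and it is large, but it replaces hydrogen rather than exchanging one group for another. Compound 3 `Cc1cc(-c2c(F)cc3c(=O)c(Cc4ccc(O)cc4)cn(C4CC4)c3c2F)cc(C)n1` follows from compound 2 by one change: 4-hydroxyphenyl in place of 1H-imidazol-2-yl on a saturated chain carbon bound to an aromatic carbon on the same saturated chain carbon bound to an aromatic carbon. Among the measured compounds shown here, no measurement yet compares these two groups, so the step from hydrogen bears only indirectly. With a substituent kept in compound 3, a return to the level of compound 1 at 15000 nM is not expected. No shift beyond the scatter is expected in either direction, and the expected change is a 1.4-fold higher number from compound 2 to compound 3 (0.13 log units; within the scatter) in this estimate. Compound 3 is estimated at 1500 nM within an expected range of 300 nM to 7000 nM in this assay when measured.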

Compound 3, half-maximal inhibitory concentration: 1500 nM
Compound 3: middle estimate and measured number agree at the digits printed; measured number inside the range.
By their numbers in this assay, from the lowest: compounds 2 and 3 (each within the scatter of the next); then compound 1.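

In this assay the exchange of 1H-imidazol-2-yl for 4-hydroxyphenyl on the saturated chain carbon gives a 1.4-fold higher number from compound 2 to compound 3 (0.13 log units; within the scatter) and so does not separate the two groups, although they differ in ring type and heavy-atom count. The step from hydrogen, a 10-fold lower number from compound 1 to compound 3 (1.00 log units; beyond the scatter) in this case, shows that the lower number at this aromatic carbon is not confined to (1H-imidazol-2-yl)methyl, as 4-hydroxybenzyl also provides it. No available evidence bears on the reason for either result.

The compounds shown leave open whether an aromatic ring is needed on the saturated chain carbon at all, a question that a simple aminomethyl or carboxylic acid group at the same aromatic carbon could address. Also open, as far as these compounds go, is how a longer chain between that carbon and the ring would read in this assay.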